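Swapping Methoxy for Methyl at Compound 3

The compounds below may be only part of what the source reports. "The series", "measured", "known", "first", "only" and "open" are said of these compounds alone.

Compound 1 `COc1cccc(-c2n[nH]cc2N2CCCNCC2)c1` gives > 10000 nM in an assay on isolated protein for binding affinity to 5-hydroxytryptamine receptor 6 (Homo sapiens) (on this read-out lower numbers stand for stronger inhibition and higher numbers for weaker inhibition), a limit of the assay rather than a number.
Compound 2 `c1ccc(-c2n[nH]cc2N2CCCNCC2)cc1` gives 3480 nM in this assay.
Compound 3 `COc1ccc(-c2n[nH]cc2N2CCNCC2)cc1` gives 279 nM in this assay.

Of the two numbers recorded, compound 3 has the lowest, and compound 2 sits higher. Compound 1 is known only through a limit (the limit of > 10000 nM in this assay, at which 1 of the 3 values shown sits). Compound 4 `Cc1ccc(-c2n[nH]cc2N2CCNCC2)cc1` has not yet been measured. It differs from compound 3 by methyl in place of methoxy on an aromatic carbon. Going by the values given here, the only measured step that touches a methoxy group is an at least 2.8-fold lower number from compound 1 to compound 2 (0.45 log units; beyond the scatter), where a hydrogen replaces that group on another core. It says that losing the methoxy had at least a modest effect there, but it does not show what a methyl does in its place. Among the compounds with values here, no measured pair exchanges methoxy for methyl. With nothing closer to lean on, the step from compound 3 to compound 4 in this assay is expected to be small, a 1.4-fold higher number from compound 3 to compound 4 (0.16 log units; within the scatter), with wide uncertainty. The estimate for compound 4 is 400 nM, between 100 nM and 1600 nM.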

Compound 4, inhibition constant: 653 nM
Compound 4: the middle estimate sits 1.6-fold (0.21 log units) below what was measured, within the range that was stated.
By their numbers in this assay, from the lowest: compound 3; then compound 4; then compound 2. At a limit, above all of these: compound 1.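

Methyl in place of methoxy, on an aromatic carbon para to a large group, gives a 2.3-fold higher number from compound 3 to compound 4 (0.37 log units; beyond the scatter) in this assay, so this position responds to the exchange and the methoxy group is not freely interchangeable with methyl here. Going by these compounds alone, the only earlier step that touches a methoxy group, an at least 2.8-fold lower number from compound 1 to compound 2 (0.45 log units; beyond the scatter), lies on another core and runs the other way, so leaving methoxy has no single direction across these two cores. Nothing among the data shown explains the size of the new step.

On these data alone, it stays open where hydrogen, chlorine, an amine or an ethoxy group at this same place would fall relative to compound 3 and compound 4. As far as these compounds go, it is also open whether the same exchange of methoxy for methyl would give a step of this size on the core of compound 1.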